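Replacing an ethoxycarbonyl chain with a 2-hydroxyethyl group

This account rests on a few compounds, and the source may have more. Where it says the series, first, only, none or still open, it means among the compounds named here.

Of the compounds shown here, three that share one core have numbers so far. In a functional assay on HL-60 cells (Homo sapiens) for cytotoxicity, read by MTT assay, with a stated time of 24 h (on this read-out higher numbers stand for weaker inhibition and lower numbers for stronger inhibition), compound 1 `COc1ccccc1N1CCN(CCCCCOc2c(Br)cc(Br)cc2Oc2ccc(Br)cc2Br)CC1` gives 32.2 ug/mL and compound 2 `CCOC(=O)C(C)Oc1c(Br)cc(Br)cc1Oc1ccc(Br)cc1Br` gives 35.7 ug/mL while compound 3 `Cc1ccc(S(=O)(=O)n2nc(N3CCN(CCCCCOc4c(Br)cc(Br)cc4Oc4ccc(Br)cc4Br)CC3)c3cc([N+](=O)[O-])ccc32)cc1` gives 52.5 ug/mL on the same scale. Scatter is the spread expected when the same measurement is simply repeated, and these three numbers all lie within it. Compound 2 therefore sits among the other two and cannot be told apart from either.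

The next candidate, compound 4 `OCCOc1c(Br)cc(Br)cc1Oc1ccc(Br)cc1Br`, has not been measured yet. The change from compound 2 to compound 4 is a single one 2-hydroxyethyl in place of 1-(ethoxycarbonyl)ethyl on an oxygen on an aromatic ring and in words it puts 2-hydroxyethyl in place of 1-(ethoxycarbonyl)ethyl on an oxygen on an aromatic ring. Going by the values given here, no measured pair shows this swap, so the expectation rests on indirect evidence. The differing side chains tested so far show no large shift, with compound 3 at 52.5 ug/mL and compound 1 at 32.2 ug/mL staying close to compound 2 at 35.7 ug/mL on this scale. The step expected is a 1.0-fold lower number from compound 2 to compound 4 (0.01 log units; within the scatter) and that estimated size lies within the scatter, so no firm direction is expected. In this assay compound 4 is expected at 35 ug/mL within a range from 15 ug/mL to 75 ug/mL as the likely span.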

Compound 4, half-maximal inhibitory concentration: 28.2 ug/mL
The estimate for compound 4 lay 1.2-fold (0.09 log units) above the measured number, and the stated range covers the measured number.
By their numbers in this assay, from the lowest: compounds 4, 1, 2 and 3 (each within the scatter of the next).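

In this assay, going by these compounds alone, the swap on the oxygen gives a 1.3-fold lower number from compound 2 to compound 4 (0.10 log units; within the scatter) and this is the first reading of a single change at this place, since the earlier compounds offered no pair differing in one place only. The change is sizeable on paper: 1-(ethoxycarbonyl)ethyl, with 7 heavy atoms and 0 hydrogen-bond donors, leaves, and 2-hydroxyethyl, with 3 heavy atoms and 1 hydrogen-bond donor, enters, yet this read-out cannot tell the two chains apart. No supporting data are available to explain this result.

One pair cannot show whether any chain on this oxygen would give a similar number, or whether these two simply happen to match. A carboxylic acid, a 2-aminoethyl group or a longer chain ending in a hydroxyl on the same oxygen would test this more widely, and a plain ethyl group would show whether the hydroxyl of compound 4 counts for anything at all.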